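The source may report more compounds than this note shows. Statements on the series, on what has been measured and on what is new or still open speak of the compounds shown alone.

Of the compounds shown here, three sharing one core have been measured in an ADME assay on S9 fraction from liver (Mus musculus) for metabolic stability, read by LC-MS, using NADPH, with a stated time of 45 min, tested at 3 uM, in the presence of a further agent that is not named here; a higher number here means that the liver removes a larger share of the compound in one pass, a lower number that the liver removes a smaller share. Compound 1, `COc1ccc(-n2cnc3cnc(Nc4cccc(NC(C)=O)c4)cc32)cc1OC`, gives 1 in this assay. Compound 2, `COc1ccc(-n2cnc3cnc(-c4cccc(NC(C)=O)c4)cc32)cc1OC`, gives 0.21 in this assay. Compound 3, `COc1ccc(-n2cnc3cnc(-c4ccccc4C)cc32)cc1OC`, gives 1 in this assay.

On these numbers compound 3 stands level with compound 1 at the digits shown, and the two together sit highest of the three; the gap between them lies within the scatter of repeated measurements. Compound 2 stands furthest from compound 3, a value lower by a margin that lies beyond the scatter, so of the three only compound 2 is clearly removed to a smaller share in one pass.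

The next compound, compound 4, is `COc1ccc(-n2cnc3cnc(-c4ccccc4OC(F)(F)F)cc32)cc1OC`. It differs from compound 3 in one place: trifluoromethoxy in place of methyl on an aromatic carbon

Within the data shown here, no step between two measured compounds touches this change, so nothing in the measured set says how the number should move. With compound 3 already at 1 in this assay, the change in compound 4 is expected to bring a step in this assay of a number 0.10 lower from compound 3 to compound 4 (within the scatter), downward at most slightly and possibly none beyond the scatter. Compound 4 is therefore estimated at 0.9 in this assay, within a range from 0.65 to 1.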

Compound 4, hepatic extraction ratio: 1
Estimate against measurement, compound 4: 0.10 below; the range from low to high includes it.
By their numbers in this assay, from the lowest: compound 2; then compounds 1, 3 and 4 (each within the scatter of the next).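

Among these compounds, putting trifluoromethoxy in place of methyl on an aromatic carbon, ortho to a large group, brings no change at the digits printed from compound 3 to compound 4 (within the scatter), and this is the first reading of any change at this position. Five heavy atoms, among them an oxygen and three fluorines, thus stand where a single carbon stood, and the number in this assay stays at the top of the fraction, where a further rise could not register, so the step shows only that this replacement does not lower the share removed in one pass. Nothing measured here offers an explanation for why the number holds at this position.

The compounds shown leave open whether any group at this place can bring the number down at all, and a carboxylic acid, a primary amine or a morpholine on the same aromatic carbon would put that to the test. Among the compounds shown here, they also leave open what separates compound 2 from compounds 3 and 4, since it differs from them in more than one place and no single step connects it to either.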